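Triazole Substituent Exchange Toward a Bromophenyl Group

The source may report more compounds than this note shows. Statements on the series, on what has been measured and on what is new or still open speak of the compounds shown alone.

Within the data shown here, compound 2 `O=c1cc(Cn2cc(CCc3ccccc3)nn2)c2ccc(O)cc2o1` holds the only full number in a functional assay on HeLa cells (Homo sapiens) for inhibition, read by MTT assay, with a stated time of 72 h; a lower number here means a stronger inhibitor, a higher number a weaker inhibitor: compound 2 gives 35100 nM. Compound 1 `CC(O)c1cn(Cc2cc(=O)oc3cc(O)ccc23)nn1` reaches only a limit in this assay, > 100000 nM. Among the measured compounds shown here, the single measured step, an at least 2.8-fold lower number from compound 1 to compound 2 (0.45 log units; beyond the scatter), rests on (the limit of > 100000 nM in this assay, at which 1 of the 2 values shown sits). Compound 3 `O=c1cc(Cn2cc(-c3ccc(Br)cc3)nn2)c2ccc(O)cc2o1` differs from compound 2 by 4-bromophenyl in place of phenethyl on an aromatic carbon. For the measured compounds named here, no measured step touches a change of this kind, and the one step known concerns a different group. The expected step is a 1.2-fold lower number from compound 2 to compound 3 (0.07 log units; within the scatter), within the scatter. Compound 3 is estimated at 30000 nM, between 8000 nM and 100000 nM.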

Compound 3, half-maximal inhibitory concentration: 40200 nM
Estimate against measurement, compound 3: 1.3-fold (0.13 log units) below; the range from low to high includes it.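

In this assay, 4-bromophenyl and phenethyl on this aromatic carbon cannot be told apart, with a 1.1-fold higher number from compound 2 to compound 3 (0.06 log units; within the scatter); each group brings one six-membered aromatic ring of carbon only. Among these compounds, compound 2 is thus no longer the only compound to read lower than the 1-hydroxyethyl compound, with an at least 2.4-fold lower number from compound 1 to compound 3 (0.39 log units; beyond the scatter). This second step also rests on a limit, not a number: the limit of > 100000 nM in this assay, at which 1 of the 3 values shown sits.

Still open, from the compounds shown here alone, is how a plain phenyl, an amine or a carboxylic acid on this aromatic carbon would read in this assay, and so whether the bromine contributes anything.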